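The source may report more compounds than this note shows. Statements on the series, on what has been measured and on what is new or still open speak of the compounds shown alone.

Working notes on the series. In an assay on isolated protein for binding affinity to leukotriene B4 receptor 1 (Homo sapiens), tested at 1 uM (on this read-out higher numbers stand for more inhibition at the one concentration tested (going by the name of the read-out) and lower numbers for less inhibition), compound 1 `C=CCc1cc(C(C)=O)c(O)cc1OCCCCCCCCC#N` gives 50%, while compound 2 `C=CCc1cc(C(C)=O)c(O)cc1OCCCCCC` gives 9%, the lowest of the two numbers. For the measured compounds named here, the single measured step, a number 41 percentage points lower from compound 1 to compound 2 (beyond the scatter), shows that shortening the chain tail costs a great deal. Compound 3 `C#CCCCCOc1cc(O)c(C(C)=O)cc1CC=C` carries the change (ethynyl in place of ethyl on a saturated chain carbon, four bonds along the chain from an oxygen on an aromatic ring). Going by the values given here, no measured step exchanges a chain terminus of equal length, so the earlier step bears on it only loosely; because the drop a number 41 percentage points lower from compound 1 to compound 2 (beyond the scatter) was large, a modest rise is expected here, a number 11 percentage points higher from compound 2 to compound 3 (beyond the scatter). Compound 3 is estimated at 20%, ranging from 5% to 45%.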

Compound 3, a percentage reported as inhibition, at one concentration (the size of the read-out at that concentration, not a potency): 29%
The estimate for compound 3 lay 9 percentage points below the measured number; measured number inside the range.
By their numbers in this assay, from the lowest: compound 2; then compound 3; then compound 1.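

In this assay, ethynyl in place of ethyl on a saturated chain carbon gives a number 20 percentage points higher from compound 2 to compound 3 (beyond the scatter), so the end of the chain matters even with the heavy-atom count of the group unchanged. Ethynyl in place of 4-cyanobutyl gives a number 21 percentage points lower from compound 1 to compound 3 (beyond the scatter), so the shorter alkyne-ended chain does not match the long nitrile-ended one. No evidence at hand accounts for either step. Still open, going by these compounds, is whether a nitrile on the shorter chain would separate chain length from the end group. Also open, on these data alone, is how a longer chain ending in ethynyl, or a chain ending in an amine or a carboxylic acid, would compare.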